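Nucleotide-linked iodoacetamides against hexokinase-2: a shortened, iodine-free analogue

A few compounds are considered here, and "the series" means these few. Any claim that something is new, unique, unknown or untested is made for them only; others in the source may bear on it.

Compound 1 `O=C(CI)NCCCNc1ncnc2c1ncn2[C@@H]1O[C@H](COP(=O)(O)OP(=O)(O)OP(=O)(O)O)[C@@H](O)[C@H]1O`: 0%
Compound 2 `O=C(CI)NCCCCC(=O)NCCCCCCNc1ncnc2c1ncn2[C@@H]1O[C@H](COP(=O)(O)OP(=O)(O)OP(=O)(O)O)[C@@H](O)[C@H]1O`: 0%
Compound 3 `O=C(CI)NCCCC(=O)NCCCCCCNc1ncnc2c1ncn2[C@@H]1O[C@H](COP(=O)(O)OP(=O)(O)OP(=O)(O)O)[C@@H](O)[C@H]1O`: 0%

In an assay on isolated protein for inhibition of hexokinase-2 (Rattus norvegicus), with a stated time of 6 h, tested at 10 mM (a higher number here means more inhibition at the concentration tested (going by the name of the read-out), a lower number less inhibition), compound 3 gives 0%. Among the compounds with values here, it stands level with compound 1 and compound 2 within the scatter, and the one measured step, no change at the digits printed from compound 2 to compound 3 (within the scatter), shows that the change at the chain carbon three bonds from the carbonyl carbon left the read-out unmoved.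

Compound 4 `CC(=O)NCCCCCCCCNc1ncnc2c1ncn2[C@@H]1O[C@H](COP(=O)(O)OP(=O)(O)OP(=O)(O)O)[C@@H](O)[C@H]1O` differs from compound 3 as follows: a group of 6 heavy atoms (4 carbon, 1 nitrogen, 1 oxygen; no ring) in place of a group of 11 heavy atoms (6 carbon, 2 nitrogen, 2 oxygen, 1 iodine; no ring), on a saturated chain carbon, six bonds along the chain from a nitrogen on an aromatic ring. Within the data shown here, no measured step covers a loss of the iodine-bearing group itself; the only step available, from compound 2 to compound 3, concerns chain length and was flat. Since all three measured compounds sit at the floor of this assay, with nothing to suggest that a change on this chain raises the read-out, the step of no change at the digits printed from compound 3 to compound 4 (within the scatter) is expected to be none beyond the scatter. Compound 4 is therefore estimated at 0%, within -5% to 10%.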

Compound 4, a percentage reported as inhibition, at one concentration (the size of the read-out at that concentration, not a potency): -12%
For compound 4 the middle estimate is 12 percentage points above the measured one, outside the stated range (below it).
By their numbers in this assay, from the lowest: compound 4; then compounds 1, 2 and 3 (each within the scatter of the next).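

In this assay, within the data shown here, the 2-acetamidoethyl group in place of the iodine-bearing group, on a saturated chain carbon, six bonds along the chain from a nitrogen on an aromatic ring, gives a number 12 percentage points lower from compound 3 to compound 4 (beyond the scatter) and is the first change in this set to move the read-out beyond the scatter. The longer iodine-bearing chain gives the same picture, with a number 12 percentage points lower from compound 2 to compound 4 (beyond the scatter) for the same kind of replacement, and the shortest gives a number 12 percentage points lower from compound 1 to compound 4 (beyond the scatter) with 5-acetamidopentyl in place of ((iodomethyl)carbonyl)amino, so the change at this position separates the iodine-free compound 4 from all three iodine-bearing compounds, though only downward. Nothing available bears on the reason for this step.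

On these data alone, whether any change on this chain can raise the read-out remains open. Also open, as far as these compounds go, is whether a terminal amine or carboxylic acid in place of the acetamide would stay level with compound 3 or fall with compound 4.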